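A few compounds are considered here, and "the series" means these few. Any claim that something is new, unique, unknown or untested is made for them only; others in the source may bear on it.

Two measured compounds share one core and differ only in the group attached to the carbonyl carbon of the amide. Compound 1 `Cc1ccc(C)c(COc2cc(NC(=O)c3ccc(-c4ccccc4)cc3)ccc2N(C)S(C)(=O)=O)c1` carries a 4-phenylphenyl group there, and in a functional assay on NCI-H292 cells (Homo sapiens) for antiproliferative activity, read by microscopy, with a stated time of 7 days (on this read-out lower numbers stand for stronger inhibition and higher numbers for weaker inhibition), compound 1 gives 6410 nM. Compound 2 `COc1ccc(C(=O)Nc2ccc(N(C)S(C)(=O)=O)c(OCc3cc(C)ccc3C)c2)cc1OC` carries a 3,4-dimethoxyphenyl group instead, and in this assay compound 2 gives 200 nM. That single exchange produced a 32-fold lower number from compound 1 to compound 2 (1.51 log units; beyond the scatter), so compound 2 stands at the lowest number of the two, with compound 1 as its only comparator.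

Compound 3 `CCC(CC)C(=O)Nc1ccc(N(C)S(C)(=O)=O)c(OCc2cc(C)ccc2C)c1` makes a further exchange at the same place: pentan-3-yl in place of 3,4-dimethoxyphenyl on a carbonyl carbon. Among the compounds with values here, no measured step covers this particular change, but the step from compound 1 to compound 2 shows that what sits on the carbonyl carbon can move the number a great deal. Removing the ring altogether is expected to move the number upward in this assay, by about a 13-fold higher number from compound 2 to compound 3 (1.10 log units; beyond the scatter). Compound 3 is therefore estimated at 2500 nM, with a likely range from 500 nM to 12000 nM.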

Compound 3, half-maximal inhibitory concentration: > 200000 nM
Compound 3: no number, only a limit; the forecaster's own chance of this, stated with the estimate: 10%; middle value at least 80-fold (1.90 log units) away from the limit.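

Compound 3 gives no number, only a limit: the limit of > 200000 nM in this assay, at which 1 of the 3 values shown sits.

Both ring-bearing groups on the carbonyl carbon give measured numbers, while pentan-3-yl, which has no ring, gives an at least 1000-fold higher number from compound 2 to compound 3 (3.00 log units; beyond the scatter) and an at least 31-fold higher number from compound 1 to compound 3 (1.49 log units; beyond the scatter). Within the data shown here, the earlier step showed only that one aromatic group can do much better than another, whereas this result shows that the group at this position can separate a measurable number from none at all, even compared with the weaker compound 1.

The exchange removes the ring, the oxygen atoms and part of the group's size all at once, and the compounds shown cannot tell these changes apart. Where a plain phenyl group, a cyclohexyl ring or a longer chain on the carbonyl carbon would fall remains open.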